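The compounds below may be only part of what the source reports. "The series", "measured", "known", "first", "only" and "open" are said of these compounds alone.

The series keeps one shared core and varies the bicyclic group on a saturated chain carbon, two bonds along the chain from an amine nitrogen in a ring. Compound 1 `c1ccc2c(c1)CC2CCCN1CCN(c2cccc3c2OCCO3)CC1` gives 646 nM in an assay on isolated protein for binding affinity to 5-hydroxytryptamine receptor 1B (Rattus norvegicus); on this read-out lower numbers stand for stronger inhibition and higher numbers for weaker inhibition. Compound 2 `c1ccc2c(c1)CCC2CCN1CCN(c2cccc3c2OCCO3)CC1` gives 417 nM in this assay, and compound 3 `c1ccc2c(c1)CC(CCN1CCN(c3cccc4c3OCCO4)CC1)C2` gives 692 nM. Compound 3 holds the highest of the three numbers, yet all three sit within the scatter of one another, so no ordering is claimed among them. The steps measured so far are small: a 1.5-fold lower number from compound 1 to compound 2 (0.19 log units; within the scatter), a 1.1-fold higher number from compound 1 to compound 3 (0.03 log units; within the scatter) and a 1.7-fold higher number from compound 2 to compound 3 (0.22 log units; within the scatter). Neither the size of the non-aromatic ring nor the point of attachment of the bicyclic group moved the number beyond the scatter.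

Compound 4 `C1=C(CCN2CCN(c3cccc4c3OCCO4)CC2)c2ccccc2C1` differs from compound 3 as follows: a group of 9 heavy atoms (9 carbon; one five-membered non-aromatic ring of carbon only, one six-membered aromatic ring of carbon only) in place of a group of 9 heavy atoms (9 carbon; one five-membered non-aromatic ring of carbon only, one six-membered aromatic ring of carbon only), on a saturated chain carbon, two bonds along the chain from an amine nitrogen in a ring; the entering group carries one double bond outside aromatic rings. Within the data shown here, no measured step touches such a double bond, so the only bearing comes from the three steps at this position, each of which stayed within the scatter. The expectation for compound 4 is therefore no step beyond the scatter, a 1.3-fold lower number from compound 3 to compound 4 (0.10 log units; within the scatter). For compound 4 the estimate in this assay is 550 nM, with a range from 250 nM to 1300 nM.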

Compound 4, inhibition constant: 251 nM
The estimate for compound 4 lay 2.2-fold (0.34 log units) above the measured number, within the range that was stated.
By their numbers in this assay, from the lowest: compounds 4, 2, 1 and 3 (each within the scatter of the next, the first and the last beyond it).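

In this assay, among these compounds, the entering group with one double bond outside aromatic rings gives the first steps at this position to pass beyond the scatter: a 2.8-fold lower number from compound 3 to compound 4 (0.44 log units; beyond the scatter) and a 2.6-fold lower number from compound 1 to compound 4 (0.41 log units; beyond the scatter). Compound 2 goes against a clean separation of compound 4 from the saturated groups, since a 1.7-fold lower number from compound 2 to compound 4 (0.22 log units; within the scatter) stays within the scatter, so the double bond sets compound 4 apart from compound 3 and compound 1 only. Nothing on hand accounts for these steps.

The compounds shown leave open whether the lower number of compound 4 would persist with a longer chain between the amine nitrogen in a ring and the entering group, or with a hydroxyl group or a methyl group added to that group. They also leave open whether the double bond would give a step of similar size in a group with a four-membered non-aromatic ring, the ring type carried by compound 1.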